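Two Linkers, One Change of the Fluorosulfonylphenyl Group

The source may report more compounds than this note shows. Statements on the series, on what has been measured and on what is new or still open speak of the compounds shown alone.

Compound 1 `CC1(C)N=C(N)N=C(N)N1c1ccc(OCCCC(=O)Nc2cccc(S(=O)(=O)F)c2)c(Cl)c1`: 7.17
Compound 2 `CC1(C)N=C(N)N=C(N)N1c1ccc(OCc2ccc(C(=O)Nc3cccc(S(=O)(=O)F)c3)cc2)c(Cl)c1`: 7.41
Compound 3 `CC1(C)N=C(N)N=C(N)N1c1ccc(OCc2ccc(C(=O)Nc3ccc(S(=O)(=O)F)cc3)cc2)c(Cl)c1`: 6.92

In an assay on isolated protein for inhibition of Dihydrofolate reductase (Mus musculus) (on this read-out lower numbers stand for lower potency and higher numbers for higher potency (the scale is a negative logarithm)), compound 1 gives 7.17, compound 2 gives 7.41 and compound 3 gives 6.92. Compound 1 and compound 2 share a core but the difference between the two cores is not broken down here; their two values lie within the scatter of each other. From compound 2 to compound 3 the change is 4-(fluorosulfonyl)phenyl in place of 3-(fluorosulfonyl)phenyl on an amide-type nitrogen, and it gave a number 0.49 log units lower from compound 2 to compound 3 (beyond the scatter). Compound 4 `CC1(C)N=C(N)N=C(N)N1c1ccc(OCCCC(=O)Nc2ccc(S(=O)(=O)F)cc2)c(Cl)c1` has not been measured; it stands to compound 1 as compound 3 stands to compound 2, with the same change 4-(fluorosulfonyl)phenyl in place of 3-(fluorosulfonyl)phenyl on an amide-type nitrogen at the same place. The step is expected to be a number 0.42 log units lower from compound 1 to compound 4 (beyond the scatter), beside the earlier one, because compound 1 starts from 7.17. Compound 4 is therefore estimated at 6.75, between 6.3 and 7.2.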

Compound 4, logarithm of the reciprocal of the active concentration, log(1/C): 7.15
Compound 4: the middle estimate sits 0.40 log units below what was measured; measured number inside the range.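

Placed on the other core, 4-(fluorosulfonyl)phenyl in place of 3-(fluorosulfonyl)phenyl on an amide-type nitrogen gave a number 0.02 log units lower from compound 1 to compound 4 (within the scatter) in this assay. The size of the step did not carry over from one core to the other: the same change on two cores in this assay, a number 0.49 log units lower (beyond the scatter) from compound 2 to compound 3 and a number 0.02 log units lower (within the scatter) from compound 1 to compound 4, 0.47 log units apart, beyond the scatter of two such steps This shows that, across these two pairs, the effect of the change depends on the core, but it does not show which difference between the cores matters or how the change would behave on any further core.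

The compounds shown leave open how a longer chain would compare with the chain of compound 1. They also leave open what a carboxylic acid or an amine in place of the fluorosulfonyl group would do in this assay.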